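Chloro to methoxy on a longer-chain purine analogue

This account rests on a few compounds, and the source may have more. Where it says the series, first, only, none or still open, it means among the compounds named here.

Compound 1 `CCCCCCC(CCO)n1cnc2c(Cl)ncnc21` is the reference point of this small set. In a functional assay on SW480 cells (Homo sapiens) for antiproliferative activity, read by MTT assay, with a stated time of 48 h (on this read-out higher numbers stand for weaker inhibition and lower numbers for stronger inhibition), compound 1 gives 16700 nM. Compound 2 `CCCCCCC(CCO)n1cnc2c(OC)ncnc21` differs from it in one spot, (methoxy in place of chloro on an aromatic carbon). For compound 2 the outcome is a limit of the assay, > 50000 nM, not a number (the limit of > 50000 nM in this assay, at which 1 of the 3 values shown sits). The step of an at least 2.9-fold higher number from compound 1 to compound 2 (0.47 log units; beyond the scatter) therefore shows that the methoxy compound is the weaker of the two, without saying by how much beyond that floor.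

Compound 3 `CCCCCCCCCCCC(CCO)n1cnc2c(Cl)ncnc21` keeps the chloro group and instead grows the side chain: pentyl in place of hydrogen on a saturated chain carbon, seven bonds along the chain from an aromatic nitrogen. In this assay compound 3 gives 5290 nM, and the step of a 3.2-fold lower number from compound 1 to compound 3 (0.50 log units; beyond the scatter) is the one clear gain in the set.

Compound 4 `CCCCCCCCCCCC(CCO)n1cnc2c(OC)ncnc21` has not yet been measured. It relates to compound 3 exactly as compound 2 relates to compound 1, by methoxy in place of chloro on an aromatic carbon, the same change on the same spot; the two cores differ only by pentyl in place of hydrogen on a saturated chain carbon, seven bonds along the chain from an aromatic nitrogen. Within the data shown here, the one measured example of this change, an at least 2.9-fold higher number from compound 1 to compound 2 (0.47 log units; beyond the scatter), points to a weaker number once the methoxy group enters. Among the measured compounds shown here, for compound 4 the expected step is therefore a 3.8-fold higher number from compound 3 to compound 4 (0.58 log units; beyond the scatter), a loss of similar size to the one seen from compound 1 to compound 2. Starting from compound 3 at 5290 nM, compound 4 is estimated to give 20000 nM in this assay, most likely between 9000 nM and 50000 nM.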

Compound 4, half-maximal inhibitory concentration: 9700 nM
For compound 4 the middle estimate is 2.1-fold (0.31 log units) above the measured one, and the stated range covers the measured number.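

In this assay methoxy in place of chloro on the core with the longer chain gives a 1.8-fold higher number from compound 3 to compound 4 (0.26 log units; within the scatter), so on this core the change cannot be told apart from the scatter of repeated measurements, and the pair does not show whether the change carries the same cost from one core to the other: the same change on two cores in this assay, an at least 2.9-fold higher number (0.47 log units; beyond the scatter) from compound 1 to compound 2 and a 1.8-fold higher number (0.26 log units; within the scatter) from compound 3 to compound 4; the limit leaves it open whether they differ. For compound 2 the entry > 50000 nM is a limit of the assay and not a number. With that caution, pentyl in place of hydrogen gives an at least 5.1-fold lower number from compound 2 to compound 4 (0.71 log units; beyond the scatter) with methoxy on the ring and a 3.2-fold lower number from compound 1 to compound 3 (0.50 log units; beyond the scatter) with chloro, so in these four compounds the longer chain goes with the lower number whichever group is present, while the sizes of the two gains cannot be compared: the same change on two cores in this assay, a 3.2-fold lower number (0.50 log units; beyond the scatter) from compound 1 to compound 3 and an at least 5.1-fold lower number (0.71 log units; beyond the scatter) from compound 2 to compound 4; the limit leaves it open whether they differ.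

The compounds shown leave open how an amine or a fluoro group on that aromatic carbon would compare with chloro and methoxy. They also leave open whether a chain longer than that of compound 3 would bring the number down further, and how large the methoxy step on the shorter chain really is.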